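Cytotoxicity of two aroylhydrazones and an expected methyl ether

This account rests on a few compounds, and the source may have more. Where it says the series, first, only, none or still open, it means among the compounds named here.

Measured compounds:
compound 1, `COc1ccc(OC)c(/C=N/NC(=O)c2ccc(-c3cccc(Cl)c3)nc2C)c1`, 188 ug/mL
compound 2, `Cc1nc(-c2ccc(Cl)cc2)ccc1C(=O)N/N=C/c1ccc(O)cc1`, 500 ug/mL

In an ADME assay on WI-38 cells (Homo sapiens) for cytotoxicity, read by colorimetric assay and crystal violet staining, with a stated time of 24 h (on this read-out higher numbers stand for weaker inhibition and lower numbers for stronger inhibition), compound 2 gives 500 ug/mL, the highest of the two numbers in hand. Among the measured compounds shown here, the only other compound, compound 1, gives 188 ug/mL in this assay, a lower number, and the gap between the two lies beyond the usual scatter; the two structures differ in more than one place, so the values are stated side by side without a step between them.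

Compound 3, `COc1ccc(/C=N/NC(=O)c2ccc(-c3ccc(Cl)cc3)nc2C)cc1`, has not yet been measured in this assay. It differs from compound 2 by methyl in place of hydrogen on an oxygen on an aromatic ring.

For the measured compounds named here, no measured pair follows this change alone, so its direction here is unknown. Since compound 1, which carries methoxy groups, gives 188 ug/mL, a modest move toward lower numbers is thought possible, but a step within the scatter is at least as plausible. The expected step from compound 2 to compound 3 in this assay is a 1.6-fold lower number from compound 2 to compound 3 (0.19 log units; within the scatter), with compound 3 estimated at 320 ug/mL, in a range from 130 ug/mL to 700 ug/mL.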

Compound 3, half-maximal inhibitory concentration: 500 ug/mL
Beside the measured number, compound 3's estimate is 1.6-fold (0.19 log units) below it, within the range that was stated.
By their numbers in this assay, from the lowest: compound 1; then compounds 2 and 3 (each within the scatter of the next).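

In this assay, among the compounds shown here, the change from 4-hydroxyphenyl to 4-methoxyphenyl gives no change at the digits printed from compound 2 to compound 3 (within the scatter), the first step in this set that follows a single change. Compound 1 and compound 2 differ in more than one place, so their values could only stand side by side, whereas this pair isolates methyl in place of hydrogen on an oxygen on an aromatic ring. In this one pair, with the rest of the structure held constant, capping the hydroxy group as a methoxy group leaves the read-out where it was, and the lower value of compound 1 finds no support in this single step. Nothing in hand explains why the number holds still across this change.

From the compounds shown here alone, whether this flat step is particular to the core of compound 2 and compound 3 or would recur on the core of compound 1 stays open, since one pair cannot establish a pattern. Also open, going by these compounds, is how the read-out would respond to a different group on that aromatic ring, such as an ethoxy group, an amine or a carboxylic acid, in place of the hydroxy or methoxy group.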